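The source may report more compounds than this note shows. Statements on the series, on what has been measured and on what is new or still open speak of the compounds shown alone.

Measured compounds:
- Compound 1, `CC(C)=CCc1cc(C(=O)Nc2cc3ccc(OCCC4CCCCN4)c(C)c3oc2=O)ccc1O`: 640 nM
- Compound 2, `CCN(CC)CCCOc1ccc2cc(NC(=O)c3ccc(O)c(CC=C(C)C)c3)c(=O)oc2c1C`: 4900 nM
- Compound 3, `CC(C)=CCc1cc(C(=O)Nc2cc3ccc(OCCCN(C)C4CCCCC4)c(C)c3oc2=O)ccc1O`: 970 nM

All three share the same core and differ only in the amine that ends the chain attached to an oxygen on an aromatic ring. In a functional assay on SK-BR-3 cells (Homo sapiens) for antiproliferative activity (on this read-out lower numbers stand for stronger inhibition and higher numbers for weaker inhibition), compound 2 gives the highest of the three numbers, that is, the weakest inhibition of the group; compound 3 lies a 5.1-fold lower number from compound 2 to compound 3 (0.70 log units; beyond the scatter) and compound 1 lies still further away, as a 7.7-fold higher number from compound 1 to compound 2 (0.88 log units; beyond the scatter) shows from the other side.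

Compound 4, `CC(C)=CCc1cc(C(=O)Nc2cc3ccc(OCCCN[C@H](C)c4ccccc4)c(C)c3oc2=O)ccc1O`, has not yet been measured. It differs from compound 2 in one place: (1-phenylethyl)amino in place of diethylamino on a saturated chain carbon, three bonds along the chain from an oxygen on an aromatic ring. Within the data shown here, the new group, like the one in compound 3, is a larger amine carrying one hydrogen-bond donor and a ring.

Among the measured compounds shown here, two measured steps bear on this change. From compound 2, the exchange to cyclohexyl(methyl)amino at the same place gave a 5.1-fold lower number from compound 2 to compound 3 (0.70 log units; beyond the scatter), and the ring-bearing amine of compound 1 gave a 7.7-fold higher number from compound 1 to compound 2 (0.88 log units; beyond the scatter) in the reverse direction. Both say that replacing diethylamino with a bulkier, ring-containing amine lowers the number in this assay by a modest amount, so a similar step is expected for compound 4, namely a 4.9-fold lower number from compound 2 to compound 4 (0.69 log units; beyond the scatter).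

Compound 4 is therefore estimated at 1000 nM, with a likely range from 400 nM to 2500 nM.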

Compound 4, half-maximal inhibitory concentration: 1000 nM
Beside the measured number, compound 4's estimate shows no gap at the digits printed; low and high end bracket the measured number.
By their numbers in this assay, from the lowest: compounds 1, 3 and 4 (each within the scatter of the next); then compound 2.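

With the (1-phenylethyl)amino group on the chain, this assay gives a 4.9-fold lower number from compound 2 to compound 4 (0.69 log units; beyond the scatter), so this is a second amine at this place, after cyclohexyl(methyl)amino, that reads clearly lower than diethylamino, and its ring is a six-membered aromatic ring of carbon only rather than a saturated one. That ring type, together with the hydrogen-bond donor and the defined stereocentre that enter with this group, leaves the number within the scatter of the two other ring-bearing amines, as a 1.0-fold higher number from compound 3 to compound 4 (0.01 log units; within the scatter) and a 1.6-fold higher number from compound 1 to compound 4 (0.19 log units; within the scatter) show, so among these four compounds only diethylamino stands apart. The data offered here contain nothing that explains this separation.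

As far as these compounds go, whether the stereocentre matters stays open, since only one hand of the (1-phenylethyl)amino group appears here, and the opposite hand could read the same or differently. Also open, from the compounds shown here alone, is where benzylamino, which keeps the aromatic ring without the extra methyl, or morpholin-4-yl, which puts an oxygen into a saturated ring, would fall on this read-out.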